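Extending a Phenyl to a Phenylethenyl on the Shared Core

The source may hold more compounds than are shown below. What is called first, only, known or untested is meant among the compounds shown, and "the series" means these compounds.

compound 1, `CC(=O)c1cc(-c2ccccc2)cc2cc(-c3ccccc3)[nH]c12`: 60.9%
compound 2, `COc1ccc(-c2cc3cc(-c4ccccc4)cc(C(C)=O)c3[nH]2)cc1`: 51.6%

Of the compounds shown here, two have been measured in a functional assay on HeLa cells (Homo sapiens) for cytotoxicity, read by MTT assay, with a stated time of 2 days, tested at 10 uM; a higher number here means a weaker effect of the compound at the concentration tested, a lower number a stronger effect. Compound 1 `CC(=O)c1cc(-c2ccccc2)cc2cc(-c3ccccc3)[nH]c12` gives 60.9%. Compound 2 `COc1ccc(-c2cc3cc(-c4ccccc4)cc(C(C)=O)c3[nH]2)cc1` gives 51.6%. The two numbers cannot be told apart: the step of a number 9.3 percentage points lower from compound 1 to compound 2 (within the scatter), methoxy in place of hydrogen on an aromatic carbon, lies within the scatter, so compound 1 stands together with compound 2 rather than apart from it.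

Compound 3 `CC(=O)c1cc(/C=C/c2ccccc2)cc2cc(-c3ccccc3)[nH]c12` has not yet been measured. It differs from compound 1 by 2-phenylethenyl in place of phenyl on an aromatic carbon. Among the compounds with values here, no measured step concerns this kind of change; the single step on record, from compound 1 to compound 2, touches a different place and was within the scatter. Nothing in the data therefore points to a shift beyond the scatter in this assay. The step of a number 2.9 percentage points lower from compound 1 to compound 3 (within the scatter) is accordingly expected to be small, within the scatter. Compound 3 is estimated to give 58% in this assay, with a range from 40% to 76%.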

Compound 3, a percentage reported as activity, at one concentration (the size of the read-out at that concentration, not a potency): 52.5%
Beside the measured number, compound 3's estimate is 5.5 percentage points above it; the range from low to high includes it.
By their numbers in this assay, from the lowest: compounds 2, 3 and 1 (each within the scatter of the next).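

In this assay, putting 2-phenylethenyl in place of phenyl gives a number 8.4 percentage points lower from compound 1 to compound 3 (within the scatter) and is the first change shown at this position, on the aromatic carbon meta to the acetyl group. The earlier step touched a different place, so only this one shows that a group of 8 heavy atoms, with 1 double bond outside aromatic rings, can replace a phenyl of 6 heavy atoms here without a shift beyond the scatter. No evidence on hand bears on this result.

With one change at this position, the compounds shown leave open whether a group of another kind there, such as an amine, a carboxylic acid or a longer chain, would move the number in this assay beyond the scatter. They also leave open how these compounds compare in potency, since the read-out gives the size of the effect at one concentration only.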